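The source may report more compounds than this note shows. Statements on the series, on what has been measured and on what is new or still open speak of the compounds shown alone.

Working notes on the series. In a functional assay on MCF7 cells (Homo sapiens) for cytotoxicity (a higher number here means a weaker inhibitor, a lower number a stronger inhibitor), compound 3 `Cc1cc(Nc2nn(CC(C)C)c(=O)c3ccccc23)n[nH]1` gives 4200 nM and stands highest of the two numbers shown; compound 2 `Cc1cc(Nc2nn(-c3ccc(F)cc3)c(=O)c3ccccc23)n[nH]1` gives 1600 nM, and a 2.6-fold higher number from compound 2 to compound 3 (0.42 log units; beyond the scatter). Compound 1 `COc1ccc(Cn2nc(Nc3cc(C)[nH]n3)c3ccccc3c2=O)cc1` gives > 30000 nM, which is a limit of the assay and not a number. Compound 4 `Cc1cc(Nc2nn(Cc3ccc([N+](=O)[O-])cc3)c(=O)c3ccccc23)n[nH]1` is not yet measured; it differs from compound 3 in one place: 4-nitrophenyl in place of isopropyl on a saturated chain carbon bound to an aromatic nitrogen. The measured step that bears on this runs the other way: an at least 7.1-fold lower number from compound 1 to compound 3 (0.85 log units; beyond the scatter), where isopropyl on that carbon took the place of 4-methoxyphenyl and the number fell by at least that much. Compound 4 puts an aryl back on the same carbon, a 4-nitrophenyl rather than a 4-methoxyphenyl, and in this assay a rise of the number is expected, plausibly of a size near an at least 7.1-fold lower number from compound 1 to compound 3 (0.85 log units; beyond the scatter); the two aryl groups differ and the size is uncertain. Compound 4 is therefore estimated at 15000 nM, range 4000 nM to 60000 nM, which would mean a 3.6-fold higher number from compound 3 to compound 4 (0.55 log units; beyond the scatter), with a limit a real possibility.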

Compound 4, half-maximal inhibitory concentration: > 30000 nM
Compound 4 was reported as a limit; the forecaster's own chance of this, stated with the estimate: 40%; middle value at least 2.0-fold (0.30 log units) from the limit.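

Putting 4-nitrophenyl in place of isopropyl on a saturated chain carbon bound to an aromatic nitrogen gives, in this assay, an at least 7.1-fold higher number from compound 3 to compound 4 (0.85 log units; beyond the scatter); a second aryl group on that carbon, with nitro rather than methoxy, therefore also goes with a number far from that of compound 3. Compound 4 gives > 30000 nM, which is a limit of the assay and not a number. The step from compound 1 to compound 4 cannot be read, because both compounds stand at the same limit: the limit of > 30000 nM in this assay, at which 2 of the 4 values shown sit.

From the compounds shown here alone, how compound 1 and compound 4 rank remains unknown. Also open, going by these compounds, is whether an unsubstituted benzyl, a benzyl carrying an amine or a carboxylic acid, or a longer chain on that aromatic nitrogen would bring the number back towards that of compound 3.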